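The source may report more compounds than this note shows. Statements on the series, on what has been measured and on what is new or still open speak of the compounds shown alone.

Working notes on the series. For the measured compounds named here, in a functional assay on Hep 3B2 cells (Homo sapiens) for inhibition, read by MTT assay, with a stated time of 72 h (a higher number here means a weaker inhibitor, a lower number a stronger inhibitor), compound 1 `CCc1nc2c(C)cc(-c3ccc(CN4CCC(O)CC4)cc3)cn2c1NC(=O)OCc1cc(Cl)cc(Cl)c1` shows "nd" (no result reported) with no result reported, and compound 2 `CCc1nc2c(C)cc(-c3ccc(CN4CCN(C)CC4)cc3)cn2c1NC(=O)OCc1cc(Cl)cc(Cl)c1` gives 4900 nM as the only number in hand, so it has no ranking yet. Compound 3 `CCc1nc2c(C)cc(-c3ccc(CNCCO)cc3)cn2c1NC(=O)OCc1cc(Cl)cc(Cl)c1` keeps the shared core and differs by (2-hydroxyethyl)amino in place of 4-methylpiperazin-1-yl on a saturated chain carbon bound to an aromatic carbon with (2-hydroxyethyl)amino in place of 4-methylpiperazin-1-yl on a saturated chain carbon bound to an aromatic carbon. Going by the values given here, no measured step bears on this change, so in this assay nothing beyond the usual scatter is expected and no direction is favoured. The expected move is a 1.0-fold higher number from compound 2 to compound 3 (0.01 log units; within the scatter) as an estimate only. Compound 3 is estimated at 5000 nM within an expected range of 2000 nM to 12000 nM for now.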

Compound 3, half-maximal inhibitory concentration: > 20000 nM
Compound 3: no number, only a limit (the forecaster's own chance of this, stated with the estimate: 12%); middle value at least 4.0-fold (0.60 log units) from the limit.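

In this assay, for the compounds shown here, (2-hydroxyethyl)amino in place of 4-methylpiperazin-1-yl on a saturated chain carbon bound to an aromatic carbon gives an at least 4.0-fold higher number from compound 2 to compound 3 (0.61 log units; beyond the scatter), which shows for the first time that the group at this position can shift the read-out beyond the scatter. Compound 3 gives > 20000 nM, a limit and not a number, so the step has a bound but no exact size: the limit of > 20000 nM in this assay, at which 1 of the 3 values shown sits.

Going by these compounds alone, compound 1 has no result, so no step to it can be read. As far as these compounds go, whether a morpholin-4-yl or dimethylamino group at this place would stay with compound 2 or with compound 3 remains open.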